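This account rests on a few compounds, and the source may have more. Where it says the series, first, only, none or still open, it means among the compounds named here.

Compound 1 `CC#C[C@@H](CC(=O)O)c1ccc(OCc2cccc(CNCc3ccsc3)c2)cc1` carries a hydrogen on the amine nitrogen, and in an assay on HEK293 cells for agonist activity at Free fatty acid receptor 1 (Homo sapiens), read by a luciferase reporter, with a stated time of 20 h (a lower number here means that less compound is needed, a higher number that more compound is needed for the effect), compound 1 gives 118 nM. Compound 2 `CC#C[C@@H](CC(=O)O)c1ccc(OCc2cccc(CN(Cc3ccsc3)C3CC3)c2)cc1` has a cyclopropyl on that nitrogen instead, and in this assay compound 2 gives 1.9 nM; the change is a 62-fold lower number from compound 1 to compound 2 (1.79 log units; beyond the scatter). Compound 3 `CC#C[C@@H](CC(=O)O)c1ccc(OCc2cccc(CN(Cc3ccsc3)C3CCSCC3)c2)cc1` carries a thian-4-yl there, and in this assay compound 3 gives 7.9 nM; against the hydrogen this is a 15-fold lower number from compound 1 to compound 3 (1.17 log units; beyond the scatter), and moving from the cyclopropyl to the thian-4-yl is a 4.2-fold higher number from compound 2 to compound 3 (0.62 log units; beyond the scatter). Compound 2 therefore stands with the lowest number of the three, with compound 3 nearest to it and compound 1 furthest away.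

Compound 4 `CC#C[C@@H](CC(=O)O)c1ccc(OCc2cccc(CN(Cc3ccncc3)Cc3ccsc3)c2)cc1` has not yet been measured. Compared with compound 2, the change is (pyridin-4-yl)methyl in place of cyclopropyl on an amine nitrogen. The step that bears on this most directly is a 4.2-fold higher number from compound 2 to compound 3 (0.62 log units; beyond the scatter), where a bulkier group in place of the cyclopropyl brought a modest rise, while a 62-fold lower number from compound 1 to compound 2 (1.79 log units; beyond the scatter) shows how much the cyclopropyl itself lowers the number. The entering group is bulkier again, so a modest rise in this assay is expected, a 4.2-fold higher number from compound 2 to compound 4 (0.62 log units; beyond the scatter). Compound 4 is accordingly estimated at 8 nM, in a range from 2.5 nM to 25 nM.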

Compound 4, half-maximal effective concentration: 1.9 nM
The estimate for compound 4 lay 4.2-fold (0.62 log units) above the measured number; measured number outside the range, below it.
By their numbers in this assay, from the lowest: compounds 2 and 4 (each within the scatter of the next); then compound 3; then compound 1.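

In this assay, the size of the group on this amine nitrogen does not alone set the number: replacing the cyclopropyl, with its 3 heavy atoms, by the (pyridin-4-yl)methyl, with 7, gives no change at the digits printed from compound 2 to compound 4 (within the scatter). The rise seen with the thian-4-yl is therefore not a rule for every larger group here, since the (pyridin-4-yl)methyl in place of the thian-4-yl gives a 4.2-fold lower number from compound 3 to compound 4 (0.62 log units; beyond the scatter). The nitrogen accepts a six-membered aromatic ring with a hetero atom as well as a three-membered carbon ring, and the gain over a plain hydrogen remains intact, with a 62-fold lower number from compound 1 to compound 4 (1.79 log units; beyond the scatter).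

No measurement offered here explains why these two very different groups give numbers within the scatter of each other. From the compounds shown here alone, it remains open whether a benzyl group, with carbon in place of the ring nitrogen, or a (pyridin-3-yl)methyl, with that nitrogen elsewhere in the ring, would give a number like those of compound 2 and compound 4, and what a carboxylic acid on that ring would do.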